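The compounds below may be only part of what the source reports. "The series", "measured", "known", "first", "only" and "open" are said of these compounds alone.

Measured so far in a functional assay on MCF cells (Homo sapiens) for antiproliferative activity, with a stated time of 72 h; on this read-out higher numbers stand for weaker inhibition and lower numbers for stronger inhibition:
- compound 1 `COc1cccc(CNc2ncnc3c2ncn3[C@@H]2O[C@H](CO)[C@@H](O)[C@H]2O)c1` gives > 166000 nM, a limit of the assay and not a number.
- compound 2 `COc1cc(CNc2ncnc3c2ncn3[C@@H]2O[C@H](CO)[C@@H](O)[C@H]2O)cc(OC)c1` gives > 166000 nM, again a limit of the assay.
- compound 3 `COc1cccc(CNc2ncnc3c2ncn3[C@@H]2O[C@H](CO)[C@@H](O)[C@H]2O)c1O` gives 20200 nM.

Compound 2 differs from compound 1 by methoxy in place of hydrogen on an aromatic carbon. The step that the two limits leave unreadable from compound 1 to compound 2 cannot be read, due to the limit of > 166000 nM in this assay, at which 2 of the 3 values shown sit. The change from compound 1 to compound 3 is hydroxy in place of hydrogen on an aromatic carbon, and it brought the step of an at least 8.2-fold lower number from compound 1 to compound 3 (0.91 log units; beyond the scatter).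

Compound 4 `COc1cc(CNc2ncnc3c2ncn3[C@@H]2O[C@H](CO)[C@@H](O)[C@H]2O)cc(OC)c1O` has not yet been measured in this assay. It differs from compound 2 by hydroxy in place of hydrogen on an aromatic carbon. Among the compounds with values here, this is the same kind of change as the one from compound 1 to compound 3, but not the same: in compound 3 the hydroxy sits ortho to a large group and ortho to a methoxy group, whereas in compound 4 it sits ortho to two methoxy groups and para to a large group. The expectation rests on compound 3, whose step an at least 8.2-fold lower number from compound 1 to compound 3 (0.91 log units; beyond the scatter) shows what this kind of change did once. For compound 4 the expected step is an at least 5.5-fold lower number from compound 2 to compound 4 (0.74 log units; beyond the scatter). Compound 4 is therefore estimated at 30000 nM, with a likely range from 8000 nM to 166000 nM.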

Compound 4, half-maximal inhibitory concentration: > 166000 nM
Compound 4 gave a limit, no number (the forecaster's own chance of this, stated with the estimate: 30%); at least 5.5-fold (0.74 log units) between middle value and limit.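

No step can be read from compound 2 to compound 4, since both stop at a limit of the assay and give no number: the limit of > 166000 nM in this assay, at which 3 of the 4 values shown sit.

The compounds shown leave open whether hydroxy in place of hydrogen changes anything in compound 4, and why compound 3, with its hydroxy elsewhere on the ring, gives a number while compound 4 does not.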